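This account rests on a few compounds, and the source may have more. Where it says the series, first, only, none or still open, it means among the compounds named here.

Measured in a functional assay on HepG2 cells (Homo sapiens) for antiproliferative activity, read by MTT assay, with a stated time of 48 h; on this read-out higher numbers stand for weaker inhibition and lower numbers for stronger inhibition:
- compound 1 `COc1ccc(-c2c(Nc3ccc(F)cc3)c3ccccc3oc2=O)cc1`: 35500 nM
- compound 2 `COc1ccc(-c2c(Nc3cccc(C(F)(F)F)c3)c3ccccc3oc2=O)cc1`: 66400 nM

Going by the values given here, compound 1, at 35500 nM, cannot be separated from compound 2, the only other measured compound. The gap between them is a 1.9-fold higher number from compound 1 to compound 2 (0.27 log units; within the scatter).

Compound 3 `COc1ccc(-c2c(Nc3ccc(F)cc3)c3ccc(O)cc3oc2=O)cc1` keeps the core and both aryl groups of compound 1 and adds one change: hydroxy in place of hydrogen on an aromatic carbon. Among the compounds with values here, no measured pair tests a change at this place. Within the data shown here, the only measured step, a 1.9-fold higher number from compound 1 to compound 2 (0.27 log units; within the scatter), puts 3-(trifluoromethyl)phenyl in place of 4-fluorophenyl on a nitrogen, so it bears on the new change only indirectly. It shows one substitution elsewhere on the core that left the number within the scatter, and it gives no direction for hydroxy.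

In this assay, no shift beyond the scatter is therefore expected, though a larger shift in either direction cannot be ruled out. The expected step is a 1.3-fold lower number from compound 1 to compound 3 (0.10 log units; within the scatter). For compound 3 the estimated value is 28000 nM, with an expected range from 9000 nM to 80000 nM.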

Compound 3, half-maximal inhibitory concentration: 65600 nM
Compound 3: middle estimate off by 2.3-fold (0.37 log units), on the low side, and the stated range covers the measured number.
By their numbers in this assay, from the lowest: compounds 1, 3 and 2 (each within the scatter of the next).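

In this assay, hydroxy in place of hydrogen on an aromatic carbon, part of a fused or bridged system of two rings, gives a 1.8-fold higher number from compound 1 to compound 3 (0.27 log units; within the scatter). Going by these compounds alone, this is the first reading at this position, and it shows that the position takes a hydroxy group with no shift that can be told from the scatter, so compound 1 and compound 3 cannot be separated. The step on the nitrogen substituent (a 1.9-fold higher number from compound 1 to compound 2 (0.27 log units; within the scatter)) also stays within the scatter, so neither of the two single changes shown separates a compound from compound 1, and no evidence is available that bears on the reason for this result.

The compounds shown leave open whether a larger or differently built group at this carbon, such as an amine, a carboxylic acid or a longer alkoxy chain, would move the number beyond the scatter. They also leave open whether hydroxy at this place would behave the same way with 3-(trifluoromethyl)phenyl on the nitrogen in place of 4-fluorophenyl.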